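A single chlorine where two fluorines stood

The compounds below may be only part of what the source reports. "The series", "measured", "known", "first", "only" and "open" are said of these compounds alone.

Three compounds share one core and differ only in the aryl group at the end of the short chain. Compound 1 `Cc1cc(NC(=O)CC(=O)O)c2c(c1Oc1ccc(O)c(CCCc3ccccc3)c1)CCC2` gives 223 nM in an in vitro assay on cells for displacement of a labelled ligand from thyroid hormone receptor beta (Homo sapiens), with a stated time of 48 h; on this read-out lower numbers stand for stronger inhibition and higher numbers for weaker inhibition. Compound 2 `Cc1cc(NC(=O)CC(=O)O)c2c(c1Oc1ccc(O)c(CCc3ccc(F)cc3F)c1)CCC2` gives 12 nM, and compound 3 `Cc1cc(NC(=O)CC(=O)O)c2c(c1Oc1ccc(O)c(CCc3ccc(F)c(F)c3)c1)CCC2` gives 6 nM; the steps of a 19-fold lower number from compound 1 to compound 2 (1.27 log units; beyond the scatter) and a 37-fold lower number from compound 1 to compound 3 (1.57 log units; beyond the scatter) were both large, whereas the step of a 2.0-fold lower number from compound 2 to compound 3 (0.30 log units; within the scatter) stayed within the scatter, so compound 2 and compound 3 sit together far below compound 1. Compound 4 `Cc1cc(NC(=O)CC(=O)O)c2c(c1Oc1ccc(O)c(CCc3cccc(Cl)c3)c1)CCC2` carries 3-chlorophenyl in place of 3,4-difluorophenyl on a saturated chain carbon, two bonds along the chain from an aromatic carbon. Among the compounds with values here, no measured step exchanges one halogen pattern for another of different count, so the size is uncertain; because a 2.0-fold lower number from compound 2 to compound 3 (0.30 log units; within the scatter) was small, compound 4 is expected to remain close to compound 3, a step of a 2.0-fold higher number from compound 3 to compound 4 (0.30 log units; within the scatter). Compound 4 is estimated at 12 nM, between 4 nM and 40 nM.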

Compound 4, inhibition constant: 41 nM
The estimate for compound 4 lay 3.4-fold (0.53 log units) below the measured number; the whole stated range lies below it.
By their numbers in this assay, from the lowest: compounds 3 and 2 (each within the scatter of the next); then compound 4; then compound 1.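

Among the difluorophenyl compounds the halogen pattern had made no difference beyond the scatter, but the 3-chlorophenyl group does, with a 6.8-fold higher number from compound 3 to compound 4 (0.83 log units; beyond the scatter) and a 3.4-fold higher number from compound 2 to compound 4 (0.53 log units; beyond the scatter) on either comparison. Even so, the aryl group on this short chain still improves on the benzyl end of compound 1, with a 5.4-fold lower number from compound 1 to compound 4 (0.74 log units; beyond the scatter) as the step. No evidence at hand accounts for the loss on going from two fluorines to one chlorine.

The compounds shown leave open whether the kind of halogen or their count matters more, which a 3-fluorophenyl or 3,4-dichlorophenyl group could separate. On these data alone, how a nitrile or methoxy group on the same ring would read also remains open.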